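Swapping the Ring on the Aromatic Carbon of Compound 2

This account rests on a few compounds, and the source may have more. Where it says the series, first, only, none or still open, it means among the compounds named here.

Of the compounds shown here, three have been tested in an ADME assay on microsomes from liver (Mus musculus) for metabolic stability, read by LC-MS, with a stated time of 10 min; a lower number here means that less of the compound is left, a higher number that more of the compound is left. Compound 1 `c1cnc2c(c1)CCC[C@@H]2N(CC1CC1)C[C@H]1Cc2c(cccc2N2CCNCC2)CN1` gives 88.3%, compound 3 `c1cnc2c(c1)CCC[C@@H]2N(CC1CCCCC1)C[C@H]1Cc2c(cccc2N2CCNCC2)CN1` gives 85.6%, and compound 2 `C[C@@H]1CN(c2cccc3c2C[C@H](CN(C)[C@H]2CCCc4cccnc42)NC3)C[C@H](C)N1` gives 85.6%. Compound 2 stands level with compound 3 at the digits shown; the two together hold the lowest numbers of the three, yet the gap to compound 1 is within the scatter. Among the measured compounds shown here, the one measured step, a number 2.7 percentage points lower from compound 1 to compound 3 (within the scatter), also lies within the scatter. Compound 4 `CN(C[C@H]1Cc2c(cccc2N2C[C@H]3C[C@@H]2CN3)CN1)[C@H]1CCCc2cccnc21` differs from compound 2 in one place: a group of 7 heavy atoms (5 carbon, 2 nitrogen; 2 five-membered non-aromatic rings with 1 hetero atom each) in place of a group of 8 heavy atoms (6 carbon, 2 nitrogen; one six-membered non-aromatic ring with 2 hetero atoms), on an aromatic carbon. For the measured compounds named here, no measured step touches this part of the shared core, and all numbers so far sit close together, so a step of a number 1.6 percentage points lower from compound 2 to compound 4 (within the scatter) is expected, nothing beyond the scatter. Compound 4 is therefore estimated at 84%, within 70% to 95%.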

Compound 4, percent of the compound remaining: 95.9%
Compound 4: the middle estimate sits 11.9 percentage points below what was measured, outside the stated range (above it).
By their numbers in this assay, from the lowest: compounds 2, 3, 1 and 4 (each within the scatter of the next, the first and the last beyond it).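

Among the compounds shown, this change on the aromatic carbon is the first single change to move the result in this assay beyond the scatter: the group with two five-membered non-aromatic rings, in place of 3,5-dimethylpiperazin-1-yl, gives a number 10.3 percentage points higher from compound 2 to compound 4 (beyond the scatter). Among the compounds shown here, the one earlier step, on a saturated chain carbon, stayed within the scatter. No measurement here offers an explanation for this rise.

On these data alone, it remains open whether the same swap does as much alongside the cyclopropyl or cyclohexyl groups of the other compounds. As far as these compounds go, how a morpholine ring would behave on this aromatic carbon is also open.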